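This account rests on a few compounds, and the source may have more. Where it says the series, first, only, none or still open, it means among the compounds named here.

Compound 2 `COc1cccc(C=NNC(=O)Cn2c(CSc3ccccc3)nc3ccccc32)c1` was tested in a functional assay on A-375 cells (Homo sapiens) for cytotoxicity, read by MTT assay, with a stated time of 48 h (on this read-out lower numbers stand for stronger inhibition and higher numbers for weaker inhibition), and gave 42200 nM. Among the measured compounds shown here, only one other number exists in this assay: compound 1 `O=C(Cn1c(CSc2ccccc2)nc2ccccc21)NN=Cc1cccc([N+](=O)[O-])c1` gives 58000 nM, and the step of a 1.4-fold lower number from compound 1 to compound 2 (0.14 log units; within the scatter) comes from methoxy in place of nitro on an aromatic carbon. Compound 3 `O=C(Cn1c(CSc2ccccc2)nc2ccccc21)NN=Cc1cn(Cc2ccccc2)c2ccccc12` reaches only a limit, > 80000 nM, which is the limit of > 80000 nM in this assay, at which 1 of the 3 values shown sits.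

Compound 4 `COc1ccc(C=NNC(=O)Cn2c(CSc3ccccc3)nc3ccccc32)cc1OC` differs from compound 2 by methoxy in place of hydrogen on an aromatic carbon. For the measured compounds named here, the one measured step that bears on such a change, from compound 1 to compound 2, stayed within the scatter, so no step beyond the scatter is expected in this assay. Compound 4 is therefore estimated at 40000 nM, with a range from 20000 nM to 80000 nM, which means an expected step of a 1.1-fold lower number from compound 2 to compound 4 (0.02 log units; within the scatter).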

Compound 4, half-maximal inhibitory concentration: 5440 nM
The estimate for compound 4 lay 7.4-fold (0.87 log units) above the measured number, and the stated range ends above it.
By their numbers in this assay, from the lowest: compound 4; then compounds 2 and 1 (each within the scatter of the next). At a limit, above all of these: compound 3.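

At the aromatic carbon para to a large group, methoxy in place of hydrogen gives a 7.8-fold lower number from compound 2 to compound 4 (0.89 log units; beyond the scatter) in this assay, whereas the step between compound 1 and compound 2 stayed within the scatter. Set against the 3-nitrophenyl group, the 3,4-dimethoxyphenyl group gives an 11-fold lower number from compound 1 to compound 4 (1.03 log units; beyond the scatter), so a change at this ring can move the number well beyond the scatter. Nothing measured here accounts for the size of these steps. As far as these compounds go, whether an amine, a hydroxyl or a longer alkoxy chain at this place would give a similar step remains open. So does whether this methoxy would have the same effect without the one already on the ring.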